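The compounds below may be only part of what the source reports. "The series", "measured", "known", "first", "only" and "open" are said of these compounds alone.

Compound 1 `CCCC/N=c1\c(O)c(O)\c1=N/Cc1ccc(C#N)cc1`: > 30000 nM
Compound 2 `Cc1cc(C#N)cc(Cl)c1C/N=c1\c(O)c(O)\c1=N/C(C)C(C)(C)C`: 1900 nM
Compound 3 `CC(C)(C)/N=c1\c(O)c(O)\c1=N/Cc1ccncc1`: 3000 nM

All three compounds were tested in a functional assay for inhibition, with Rattus norvegicus as the target; a higher number here means a weaker inhibitor, a lower number a stronger inhibitor. Compound 1 gives no number, only the limit > 30000 nM. Compound 2 gives 1900 nM and compound 3 gives 3000 nM, two values within the usual scatter of each other.

Compound 4 `CC[C@@H](C)/N=c1\c(O)c(O)\c1=N/Cc1ccc(C#N)cc1` has not yet been measured. It keeps everything in compound 1 except for one change, sec-butyl in place of butyl on a double-bonded nitrogen. The two compounds have the same atoms, joined differently.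

Going by the values given here, no measured pair isolates this change, so the expectation rests on indirect evidence. Compound 2 at 1900 nM and compound 3 at 3000 nM both carry a branched group on that nitrogen, although each also differs from compound 1 elsewhere. On that basis, a move toward stronger inhibition is expected, though with much uncertainty. The expected size of that move is an at least 7.5-fold lower number from compound 1 to compound 4 (0.87 log units; beyond the scatter). The estimate for compound 4 is 4000 nM, with an expected range from 800 nM to 25000 nM.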

Compound 4, half-maximal inhibitory concentration: 4000 nM
Beside the measured number, compound 4's estimate shows no gap at the digits printed; the range from low to high includes it.
By their numbers in this assay, from the lowest: compounds 2, 3 and 4 (each within the scatter of the next, the first and the last beyond it). At a limit, above all of these: compound 1.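

In this assay, going by these compounds alone, this is the first pair that isolates the group on the double-bonded nitrogen: with the rest of the compound unchanged, sec-butyl in place of butyl gives an at least 7.5-fold lower number from compound 1 to compound 4 (0.87 log units; beyond the scatter). The earlier compounds shown here also carry branched groups on that nitrogen, but each differs from compound 1 elsewhere as well, whereas here butyl and sec-butyl have the same heavy atoms, so the step follows a rearrangement of the chain and not an added atom, and it brings in a defined stereocentre. The true size of the step cannot be read, only its lower bound, because compound 1 stands at a limit of the assay: the limit of > 30000 nM in this assay, at which 1 of the 4 values shown sits.

The compounds shown leave open whether the mirror-image form of sec-butyl would give a similar number in this assay, and how an isopropyl or a cyclopropyl group on the same nitrogen would compare with sec-butyl. Also open, going by these compounds, is whether the step from butyl to sec-butyl would hold with an amine or a carboxylic acid in place of the nitrile.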